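This account rests on a few compounds, and the source may have more. Where it says the series, first, only, none or still open, it means among the compounds named here.

Compound 1 `COc1cc(N(Cc2nc3ccccc3[nH]2)S(=O)(=O)c2ccc(F)cc2)cc(OC)c1OC`: 5680 nM
Compound 2 `COc1cc(N(Cc2nc3ccccc3[nH]2)S(=O)(=O)c2ccc(C(C)(C)C)cc2)cc(OC)c1OC`: 24100 nM
Compound 3 `COc1ccc(S(=O)(=O)N(Cc2nc3ccccc3[nH]2)c2cc(OC)c(OC)c(OC)c2)cc1OC`: 22500 nM

All three were measured in a functional assay on MGC-803 cells (Homo sapiens) for inhibition, read by MTT assay, with a stated time of 48 h; on this read-out higher numbers stand for weaker inhibition and lower numbers for stronger inhibition. Among them compound 1 stands lowest; the step of a 4.0-fold higher number from compound 1 to compound 3 (0.60 log units; beyond the scatter) and the step of a 4.2-fold higher number from compound 1 to compound 2 (0.63 log units; beyond the scatter) are both beyond the scatter and of similar size, while compound 2 and compound 3 lie within the scatter of each other, as the step of a 1.1-fold lower number from compound 2 to compound 3 (0.03 log units; within the scatter) shows.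

Compound 4 `COc1cc(N(Cc2nc3ccccc3[nH]2)C(=O)c2ccccc2)cc(OC)c1OC` has not yet been measured. It differs from compound 1 in one place: benzoyl in place of (4-fluorophenyl)sulfonyl on a nitrogen on an aromatic ring. The two measured steps that start from compound 1 both change only the aryl group that sits on the sulfonyl sulfur, and both moved the number upward by a modest amount. Among the compounds with values here, the change to compound 4 is of a different kind, since the sulfonyl itself leaves and a benzoyl enters, so no measured step speaks to it directly. What the data do show is that every departure from compound 1 so far has given a higher number in this assay. On that basis compound 4 is expected to give a modestly higher number than compound 1, with the step of a 2.1-fold higher number from compound 1 to compound 4 (0.32 log units; beyond the scatter) estimated to lie in the range of the two measured steps, though the uncertainty is wide. The estimate for compound 4 is 12000 nM, with a range from 4000 nM to 40000 nM.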

Compound 4, half-maximal inhibitory concentration: > 50000 nM
Compound 4 was reported as a limit; the forecaster's own chance of this, stated with the estimate: 10%; at least 4.1-fold (0.61 log units) between middle value and limit.
By their numbers in this assay, from the lowest: compound 1; then compounds 3 and 2 (each within the scatter of the next). At a limit, above all of these: compound 4.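

In this assay, compound 4 gives no number, only a limit: the limit of > 50000 nM in this assay, at which 1 of the 4 values shown sits.

The earlier steps shown here changed only the aryl group on the sulfonyl sulfur, whereas this one replaces the sulfonyl itself on the nitrogen on an aromatic ring, and it gives an at least 8.8-fold higher number from compound 1 to compound 4 (0.94 log units; beyond the scatter). Among the compounds shown, then, the sulfonyl-bearing compound 1 keeps a measurable number in this assay, and the benzoyl in its place does not, so this position is sensitive to the change of the group attached to that nitrogen and not only to the aryl group it carries.

The step also removes the fluoro substituent along with the sulfonyl, so the compounds shown cannot tell how much of the loss belongs to the carbonyl replacing the sulfonyl and how much to the missing fluorine, a question that a 4-fluorobenzoyl group on the same nitrogen would address. They also leave open whether the aryl ring on the sulfonyl is needed at all, as a methylsulfonyl group or a simple benzyl group at this place would show.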